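This account rests on a few compounds, and the source may have more. Where it says the series, first, only, none or still open, it means among the compounds named here.

Compound 1 `CCOC(=O)c1ccc(Nc2cc(C)nc(-c3ccncc3)n2)cc1` and compound 3 `CCOC(=O)c1ccc(Nc2ccnc(-c3cccnc3)n2)cc1` share the ethoxycarbonyl-bearing aniline but sit on two different cores; the difference between the two cores is not broken down here. Within the data shown here, in a physicochemical assay for solubility, in phosphate buffer (a lower number here means a less soluble compound, a higher number a more soluble compound), compound 1 gives 4000 nM, whereas compound 3 gives 61000 nM, the highest of the three numbers measured so far. Compound 2 `CC(=O)c1ccc(Nc2cc(C)nc(-c3ccncc3)n2)cc1` is compound 1 with one change, (methyl in place of ethoxy on a carbonyl carbon). In this assay compound 2 gives 6000 nM, so the step was a 1.5-fold higher number from compound 1 to compound 2 (0.18 log units; within the scatter).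

Compound 4 `CC(=O)c1ccc(Nc2ccnc(-c3cccnc3)n2)cc1` is compound 3 carrying the same change, (methyl in place of ethoxy on a carbonyl carbon); the place of the change is described identically for both pairs. It has not yet been measured in this assay. Among the measured compounds shown here, the one precedent for this change is the step from compound 1 to compound 2, which stayed within the scatter, so the expectation for compound 4 rests on that single step carrying over to the core of compound 3. On that basis compound 4 is expected to land at about 80000 nM in this assay, an estimated step of a 1.3-fold higher number from compound 3 to compound 4 (0.12 log units; within the scatter) from compound 3. For the measured compounds named here, because the only precedent is a 1.5-fold higher number from compound 1 to compound 2 (0.18 log units; within the scatter), the estimate for compound 4 is expected to fall anywhere from 35000 nM to 180000 nM. Whether compound 4 indeed keeps close to compound 3 is what the measurement will show.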

Compound 4, solubility: 98000 nM
Compound 4: middle estimate off by 1.2-fold (0.09 log units), on the low side; the measured number falls inside the stated range.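

In this assay, replacing ethoxy with methyl on a carbonyl carbon, the change that reads as ethoxycarbonyl to acetyl, gives a 1.6-fold higher number from compound 3 to compound 4 (0.21 log units; within the scatter), and on the other core the same change gives a 1.5-fold higher number from compound 1 to compound 2 (0.18 log units; within the scatter), so the step lies within the scatter on both cores. Among these compounds, this shows that, in these two pairs, the change left no step that can be told apart from repeated measurement, whichever of the two cores carried it; it does not show that a real effect of a particular size carries from one core to the other, and two pairs establish no rule for any further core. Nothing given here offers an explanation for the result on either core.

The compounds shown leave open whether an amine or a longer chain such as propoxy, placed on the same carbonyl carbon, would also stay within the scatter on both cores, or would instead give a step that differs from one core to the other. They also leave open which part of the difference between the two cores goes with the values in this assay, as no pair shown separates those parts.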